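Chloro for hydrogen on a fused two-ring core, applied twice

A few compounds are considered here, and "the series" means these few. Any claim that something is new, unique, unknown or untested is made for them only; others in the source may bear on it.

Compound 1 `ClCc1ccccc1Cn1cnc2c(Cl)nc(Cl)nc21` and compound 2 `ClCc1ccccc1Cn1cnc2c(Cl)ncnc21` share a core and differ in one place. In a functional assay on A498 cells (Homo sapiens) for cytotoxicity, read by sulforhodamine B assay, with a stated time of 48 h (a higher number here means that more compound is tolerated, a lower number that less compound is tolerated), compound 1 gives 9550 nM, while compound 2 gives 58900 nM. The step of a 6.2-fold lower number from compound 2 to compound 1 (0.79 log units; beyond the scatter) is the change (chloro in place of hydrogen on an aromatic carbon), and the size of that step comes from the two measured values alone.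

Compound 3 `ClCc1cccc(Cn2cnc3c(Cl)ncnc32)c1` is built from the same atoms as compound 2, joined differently; the difference between the two cores is not broken down here. In this assay compound 3 gives 58900 nM, level with compound 2 at the digits recorded, so no order between the two is claimed.

Compound 4 `ClCc1cccc(Cn2cnc3c(Cl)nc(Cl)nc32)c1` has not yet been measured. It differs from compound 3 by chloro in place of hydrogen on an aromatic carbon. The place is described in the same words as for the change from compound 2 to compound 1, so this is the same change made on the core of compound 3. For the measured compounds named here, with only the one earlier instance to rest on, the expectation is that the step of a 6.2-fold lower number from compound 3 to compound 4 (0.79 log units; beyond the scatter) in this assay will be of about the size seen for a 6.2-fold lower number from compound 2 to compound 1 (0.79 log units; beyond the scatter), since compound 3 starts from 58900 nM, the same number as compound 2. On that basis compound 4 is estimated to give 9500 nM in this assay, with a plausible range from 4000 nM to 25000 nM.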

Compound 4, concentration lethal to 50% of the cells: 27500 nM
Compound 4: middle estimate off by 2.9-fold (0.46 log units), on the low side; the measured number lies above the stated range.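

In this assay, chloro in place of hydrogen on the aromatic carbon between two ring nitrogen atoms gives a 2.1-fold lower number from compound 3 to compound 4 (0.33 log units; beyond the scatter), so the number falls on this core as it did on the core of compound 2. The direction of the change therefore carries from one core to the other, but its size does not carry over unchanged: the same change on two cores in this assay, a 6.2-fold lower number (0.79 log units; beyond the scatter) from compound 2 to compound 1 and a 2.1-fold lower number (0.33 log units; beyond the scatter) from compound 3 to compound 4, 2.9-fold (0.46 log units) apart, beyond the scatter of two such steps. These two instances show that the size of the step depends on the core it is made on, but they do not show what in the different joining of the two cores sets that size, nor how the change would behave on any further core.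

At the aromatic carbon between the two ring nitrogen atoms, the compounds shown carry only hydrogen or chloro, so it remains open what an amine, a methoxy group or a longer chain would do at that place on either core. As far as these compounds go, the other chloro group on the six-membered ring with two nitrogen atoms is present in all four compounds, so it is also open how the step would look with an amine in its place.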